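A few compounds are considered here, and "the series" means these few. Any claim that something is new, unique, unknown or untested is made for them only; others in the source may bear on it.

Compound 1 `NC(=O)c1c(NC(=O)c2ccccc2Cl)sc2c1CCN(Cc1ccc(Cl)cc1)C2` gives > 50000 nM in a functional assay on HeLa cells (Homo sapiens) for antiproliferative activity, with a stated time of 24 h; a higher number here means a weaker inhibitor, a lower number a stronger inhibitor; this is a limit of the assay.
Compound 2 `NC(=O)c1c(NC(=O)c2ccccc2Cl)sc2c1CCN(C(=S)Nc1ccccc1I)C2` gives 29000 nM in this assay.
Compound 3 `COc1ccccc1NC(=S)N1CCc2c(sc(NC(=O)c3ccccc3Cl)c2C(N)=O)C1` gives > 50000 nM in this assay; this too is a limit.

Compound 3 therefore stands at the limit (the limit of > 50000 nM in this assay, at which 2 of the 3 values shown sit), and no number marks it on this scale. The measured steps all alter the group on the ring amine nitrogen: the step from compound 1 to compound 2 reads an at least 1.7-fold lower number from compound 1 to compound 2 (0.23 log units; that floor lies within the scatter), that from compound 1 to compound 3 reads a step that the two limits leave unreadable from compound 1 to compound 3, and that from compound 2 to compound 3 reads an at least 1.7-fold higher number from compound 2 to compound 3 (0.23 log units; that floor lies within the scatter). Compound 4 `COc1ccccc1NC(=S)N1CCc2c(sc(NC(=O)c3ccccc3OC)c2C(N)=O)C1` differs from compound 3 at the other end of the molecule: methoxy in place of chloro on an aromatic carbon. Going by the values given here, none of the measured steps touches this ring, so none of them gives a size or a direction for the change. The step from compound 3 to compound 4 is therefore expected to be a number no higher from compound 3 to compound 4 (the limit leaves the size open), nothing beyond the scatter. Compound 4 is expected to stay at the limit, with an estimate of 50000 nM and a range from 20000 nM to 50000 nM.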

Compound 4, half-maximal inhibitory concentration: > 50000 nM
Compound 4 was reported as a limit; the forecaster's own chance of this, stated with the estimate: 80%; the middle value lies on the limit itself.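

Compound 3 and compound 4 both stand only at a limit in this assay, so no step between them can be read: the limit of > 50000 nM in this assay, at which 3 of the 4 values shown sit.

The compounds shown leave open whether methoxy in place of chloro on this aromatic carbon changes the read-out at all.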